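Removing bromine from a sulfonate ester and a phenol core

The source may hold more compounds than are shown below. What is called first, only, known or untested is meant among the compounds shown, and "the series" means these compounds.

Compound 1, `C=C1C[C@]23C[C@@]1(O)CC[C@H]2c1ccc(OS(=O)(=O)c2ccc(C)cc2)c(C)c1[C@@H]3Cn1cc(-c2ccc(Br)cc2)nn1`: in a functional assay on SW480 cells (Homo sapiens) for cytotoxicity, read by MTT assay, with a stated time of 4 days (a higher number here means a weaker inhibitor, a lower number a stronger inhibitor), compound 1 gives > 20000 nM, which is a limit of the assay and not a number.
Compound 2, `C=C1C[C@]23C[C@@]1(O)CC[C@H]2c1ccc(OS(=O)(=O)c2ccc(C)cc2)c(C)c1[C@@H]3Cn1cc(-c2ccccc2)nn1`: in this assay compound 2 gives > 20000 nM, again a limit and not a number.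
Compound 3, `C=C1C[C@]23C[C@@]1(O)CC[C@H]2c1cc(Br)c(O)c(C)c1[C@@H]3Cn1cc(-c2ccc(Cl)cc2)nn1`: in this assay compound 3 gives 18000 nM.

Compound 1 and compound 2 differ by hydrogen in place of bromo on an aromatic carbon. The resulting step, a step that the two limits leave unreadable from compound 1 to compound 2, cannot be sized, and this rests on (the limit of > 20000 nM in this assay, at which 2 of the 3 values shown sit). The difference between the core of compound 1 and the core of compound 3 is not broken down here.

Compound 4, `C=C1C[C@]23C[C@@]1(O)CC[C@H]2c1ccc(O)c(C)c1[C@@H]3Cn1cc(-c2ccc(Cl)cc2)nn1`, has not yet been measured. It differs from compound 3 by hydrogen in place of bromo on an aromatic carbon. This is the same kind of change as that from compound 1 to compound 2, but the place differs: in compound 3 the bromo sits ortho to a hydroxy group, meta to a fused ring and meta to a methyl group, whereas in compound 1 it sat para to a large group. Since the earlier step could not be read, there is no measured guide for its size. Compound 4 is expected to sit near compound 3, with an estimated step of a 1.4-fold higher number from compound 3 to compound 4 (0.14 log units; within the scatter), and quite possibly to reach the limit. The estimate for compound 4 in this assay is 25000 nM, within 8000 nM to 60000 nM.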

Compound 4, half-maximal inhibitory concentration: > 20000 nM
Compound 4: a limit, no number; the forecaster's own chance of this, stated with the estimate: 60%; the middle value lies beyond the limit too.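

In this assay compound 4 gives > 20000 nM, which is a limit of the assay and not a number. From the compounds shown here alone, replacing the bromo with hydrogen on this phenol core gives an at least 1.1-fold higher number from compound 3 to compound 4 (0.04 log units; that floor lies within the scatter); this is only a floor, and the true size of the step remains unknown. The same replacement on the sulfonate ester core cannot be read either, so nothing shows whether the change behaves alike on the two cores, and the comparison fails for one reason: the limit of > 20000 nM in this assay, at which 3 of the 4 values shown sit.

Going by these compounds, it remains open what a different group would do at this place, ortho to a hydroxy group: an amine or a carboxylic acid in place of the bromo might or might not give a value that can be read as a number. Also open, on these data alone, is what removing a bromo does to a pair of compounds that both give numbers; only such a pair could size this change.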